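A few compounds are considered here, and "the series" means these few. Any claim that something is new, unique, unknown or untested is made for them only; others in the source may bear on it.

Compound 1 `COC(=O)N(C)C(C)C#CCN1CCCC1` and compound 2 `COC(=O)N(C)C(C)C#CCn1ccnc1` share one core; compound 3 `CCOC(=O)N(C)CC#CCN1CCCC1` is built from the same atoms joined differently, and how the two cores differ is not broken down here. In a functional assay on the whole organism for antagonist activity, with Mus musculus as the target (on this read-out lower numbers stand for an effect already at smaller amounts and higher numbers for an effect only at larger amounts of compound), compound 1 gives > 100 mg/kg, which is a limit of the assay and not a number. Compound 2 gives > 100 mg/kg in this assay, again a limit. Compound 3 gives > 100 mg/kg in this assay, also a limit.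

The change from compound 1 to compound 2 is 1H-imidazol-1-yl in place of pyrrolidin-1-yl on a saturated chain carbon bound to a triple-bonded carbon. Its size is a step that the two limits leave unreadable from compound 1 to compound 2, since the limit of > 100 mg/kg in this assay, at which 3 of the 3 values shown sit, puts every value at the edge of what the assay can read.

Compound 4 `CCOC(=O)N(C)CC#CCn1ccnc1` differs from compound 3 by 1H-imidazol-1-yl in place of pyrrolidin-1-yl on a saturated chain carbon bound to a triple-bonded carbon, the same change, at the same place.

The step from compound 3 to compound 4 in this assay is expected to be a step that the limit leaves unreadable from compound 3 to compound 4, because the limit of > 100 mg/kg in this assay, at which 3 of the 3 values shown sit, leaves the earlier step without a readable size. Compound 4 is therefore expected to give about 150 mg/kg in this assay, with a range from 50 mg/kg to 500 mg/kg, most likely again reported only as a limit.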

Compound 4, dose for half-maximal effect: 97 mg/kg
Estimate against measurement, compound 4: 1.5-fold (0.19 log units) above; the range from low to high includes it.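

In this assay, 1H-imidazol-1-yl in place of pyrrolidin-1-yl gives an at least 1.0-fold lower number from compound 3 to compound 4 (0.01 log units; that floor lies within the scatter), which is only a floor for the step and does not establish a real difference. Among these compounds, compound 4 gives 97 mg/kg, the only value among the four compounds that is a number and not a limit. The step from compound 1 to compound 2 cannot be read, so the change cannot be compared between the two cores, and carry-over from one core to the other is neither confirmed nor ruled out, because so much of the data sits at the edge of the read-out: the limit of > 100 mg/kg in this assay, at which 3 of the 4 values shown sit.

As far as these compounds go, it remains open whether the change would give a readable step on a core where the pyrrolidin-1-yl compound itself gives a number. Also open, from the compounds shown here alone, is how a piperidin-1-yl group or a dimethylamino group would read in the same place in this assay.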